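Compound 3: same atoms as compound 2, configuration undrawn

A few compounds are considered here, and "the series" means these few. Any claim that something is new, unique, unknown or untested is made for them only; others in the source may bear on it.

Measured so far in a functional assay on the whole organism with Mus musculus as the target, in the maximal electroshock model, with a stated time of 0.5 h (a lower number here means that less compound is needed, a higher number that more compound is needed for the effect), as follows:
- compound 1 `CC[C@]1(c2ccccc2)OC(=O)NC1=O` gives 91 mg/kg 
- compound 2 `CC[C@]1(c2ccccc2)OC(=O)N(C)C1=O` gives 122 mg/kg 

Among the compounds with values here, compound 2 stands within the scatter of compound 1, its only measured neighbour. Between them lies a 1.3-fold higher number from compound 1 to compound 2 (0.13 log units; within the scatter) as the sole measured step, which places methyl in place of hydrogen on an amide-type nitrogen in a ring.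

Compound 3 `CCC1(c2ccccc2)OC(=O)N(C)C1=O` is the next entry. Its difference from compound 2 is the two compounds have the same atoms and bonds; at least one stereo element is drawn with a configuration in one of them and without one in the other: 1 of 1 stereo elements differ; a stereocentre at a saturated ring carbon is drawn R in compound 2 and without a configuration in compound 3 in that a stereocentre at a saturated ring carbon is drawn R in compound 2 and without a configuration in compound 3.

Within the data shown here, no measured step tests a change of drawn configuration, so the data offer no direct guide. In this assay no step beyond the scatter is expected, and no direction is favoured. The expected change is a 1.0-fold lower number from compound 2 to compound 3 (0.01 log units; within the scatter) as estimated here. Compound 3 is estimated at 120 mg/kg with an expected range from 75 mg/kg to 190 mg/kg for now.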

Compound 3, dose for half-maximal effect: 124 mg/kg
Compound 3: the middle estimate sits 1.0-fold (0.01 log units) below what was measured, within the range that was stated.
By their numbers in this assay, from the lowest: compounds 1, 2 and 3 (each within the scatter of the next).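

Within the data shown here, compound 2 and compound 3 give the first measured look at the stereocentre at the saturated ring carbon, since the earlier step changed only the methyl on the amide-type nitrogen. In this assay the change of drawn configuration gives a 1.0-fold higher number from compound 2 to compound 3 (0.01 log units; within the scatter), so removing the drawn R from this centre moves the number by no more than the scatter. With the methyl held constant, the pair carries a single difference: the fact that one of compounds 2 and 3 is drawn with a defined configuration and the other without, at the place where they differ.

The series leaves open whether a compound drawn with the opposite configuration at this centre would stay within the scatter of compound 2, and whether the same holds for the hydrogen-bearing nitrogen of compound 1. It also leaves open what a longer chain in place of the ethyl, or an amine on the shared core, would do in this assay.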